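A few compounds are considered here, and "the series" means these few. Any claim that something is new, unique, unknown or untested is made for them only; others in the source may bear on it.

In a functional assay on HEL cells (Homo sapiens) for cytotoxicity (a lower number here means that less compound is tolerated, a higher number that more compound is tolerated), compound 1 (`C=CC[C@@H]1O[C@@H]2CO[C@@H](c3ccccc3)O[C@H]2[C@H](OC)[C@H]1OC`) has "not determined" (no result reported). Compound 2 (`CO[C@@H]1[C@@H](OC)[C@H](Cc2ccccc2)O[C@@H]2CO[C@@H](c3ccccc3)O[C@@H]12`) gives > 50 ug/mL, which is a limit of the assay and not a number. Compound 3 (`CO[C@@H]1[C@@H](OC)[C@H](c2ccccc2)O[C@@H]2CO[C@@H](c3ccco3)O[C@@H]12`) has "not determined" (no result reported), so it holds no place on the numbers and offers no direct baseline. Compound 4 (`CO[C@@H]1[C@@H](OC)[C@H](c2ccccc2)O[C@@H]2CO[C@@H](c3ccc(Cl)cc3)O[C@@H]12`) has yet to be measured. The structural change is 4-chlorophenyl in place of furan-2-yl on a saturated ring carbon, with 4-chlorophenyl in place of furan-2-yl on a saturated ring carbon. Within the data shown here, no measured pair shows what such a change does in this assay, so no step beyond the usual scatter is expected, in either direction. The half-maximal cytotoxic concentration of compound 4 is estimated at 50 ug/mL, with an expected range of 20 ug/mL to 100 ug/mL.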

Compound 4, half-maximal cytotoxic concentration: > 50 ug/mL
Compound 4 gave a limit, no number (the forecaster's own chance of this, stated with the estimate: 70%); the middle value lies on the limit itself.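

Compound 4 gives > 50 ug/mL, a limit of the assay and not a number, and compound 3 has no result, so no step can be read between them. The compounds shown leave open how 4-chlorophenyl and furan-2-yl compare at this place on the shared core.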